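A few compounds are considered here, and "the series" means these few. Any claim that something is new, unique, unknown or untested is made for them only; others in the source may bear on it.

Values measured so far in a functional assay on DU-145 cells (Homo sapiens) for antiproliferative activity, read by propidium iodide staining, with a stated time of 96 h (a higher number here means a weaker inhibitor, a lower number a stronger inhibitor), are as follows.

Compound 1 (`CC(O)(COc1cccc(S(F)(F)(F)(F)F)c1)C(=O)Nc1ccc(C#N)c(C(F)(F)F)c1`) gives 16000 nM
Compound 2 (`CC(O)(CS(=O)(=O)c1ccccc1C(F)(F)F)C(=O)Nc1ccc(S(F)(F)(F)(F)F)cc1`) gives 29400 nM

These two values lie within the scatter of each other, so compound 2 cannot be ranked against compound 1 on these numbers. Going by the values given here, no measured pair differs in one place, which leaves the data without a measured step to draw on.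

Compound 3 (`CC(O)(CS(=O)(=O)c1ccccc1OC(F)(F)F)C(=O)Nc1ccc(S(F)(F)(F)(F)F)cc1`) has not yet been measured. Compared with compound 2, it has trifluoromethoxy in place of trifluoromethyl on an aromatic carbon, ortho to a large group (trifluoromethoxy in place of trifluoromethyl on an aromatic carbon). Among the compounds with values here, with no measured precedent for this change, the expectation starts from compound 2 at 29400 nM in this assay and assumes no step beyond the scatter in either direction. The estimated change is a 1.2-fold lower number from compound 2 to compound 3 (0.07 log units; within the scatter) and it is expected to stay within the scatter. For compound 3 the estimated value is 25000 nM with an expected range from 10000 nM to 60000 nM in this read-out.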

Compound 3, half-maximal inhibitory concentration: 19500 nM
Beside the measured number, compound 3's estimate is 1.3-fold (0.11 log units) above it; low and high end bracket the measured number.
By their numbers in this assay, from the lowest: compounds 1, 3 and 2 (each within the scatter of the next).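

In this assay, going by these compounds alone, the first one-place step, trifluoromethoxy in place of trifluoromethyl on an aromatic carbon, ortho to a large group, gives a 1.5-fold lower number from compound 2 to compound 3 (0.18 log units; within the scatter) and therefore cannot be told from repeat-measurement noise. At this position, the two fluorinated groups cannot be ranked, and the oxygen that enters, with its one counted hydrogen-bond acceptor, leaves no resolved mark on the antiproliferative read-out. No measurement is available here that could account for this result.

Whether a chemically different group at this position, such as an amine, a carboxylic acid or a longer chain, would give a step beyond the scatter remains open, since only trifluoromethyl and trifluoromethoxy are shown there. Also open, from the compounds shown here alone, is whether the same exchange would behave alike at another position on this ring or on a different core, and compound 1 cannot settle this, as it differs from compound 2 and compound 3 in more than one place.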